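The compounds below may be only part of what the source reports. "The series", "measured", "known", "first", "only" and "open" are said of these compounds alone.

In a functional assay on MCF7 cells (Homo sapiens) for cytotoxicity, read by MTT assay, with a stated time of 72 h (on this read-out lower numbers stand for stronger inhibition and higher numbers for weaker inhibition), compound 2 `N[C@H]1CC[C@H](Nc2c(C(=O)NCc3ccc(F)cc3)nc(Br)c3cccnc23)CC1` gives 2000 nM and compound 3 `NCCCNc1c(C(=O)NCc2ccc(F)cc2)nc(Br)c2cccnc12` gives 6000 nM; for compound 1 `CS(=O)(=O)Oc1c(C(=O)NCc2ccc(F)cc2)nc(Br)c2cccnc12` the entry reads "not determined" (no result reported), so no number is available there. Compound 3 thus stands highest of the two numbers, with compound 2 as its nearest neighbour, and the step of a 3.0-fold higher number from compound 2 to compound 3 (0.48 log units; beyond the scatter) is a modest one. Compound 4 `NCCCCCCNc1c(C(=O)NCc2ccc(F)cc2)nc(Br)c2cccnc12` differs from compound 3 by 3-aminopropyl in place of amino on a saturated chain carbon, three bonds along the chain from a nitrogen on an aromatic ring. Within the data shown here, no measured step lengthens a chain in this way; the one measured step exchanges 4-aminocyclohexyl for 3-aminopropyl, a different kind of change, and so gives little guidance. A step within the scatter is therefore expected, no change at the digits printed from compound 3 to compound 4 (within the scatter). Compound 4 is expected to give 6000 nM, with a range from 2000 nM to 18000 nM.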

Compound 4, half-maximal inhibitory concentration: 2000 nM
Beside the measured number, compound 4's estimate is 3.0-fold (0.48 log units) above it; the measured number falls inside the stated range.
By their numbers in this assay, from the lowest: compounds 2 and 4 (each within the scatter of the next); then compound 3.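

In this assay, 6-aminohexyl in place of 3-aminopropyl on a nitrogen on an aromatic ring gives a 3.0-fold lower number from compound 3 to compound 4 (0.48 log units; beyond the scatter) and shows that chain length at this place matters for these compounds. Going from 4-aminocyclohexyl to 6-aminohexyl gives no change at the digits printed from compound 2 to compound 4 (within the scatter) and shows that, in this pair, an open chain can match the cyclohexyl ring. No measurement shown here explains the effect of chain length. Still open, as far as these compounds go, is how 4-aminobutyl and 5-aminopentyl would compare. From the compounds shown here alone, a longer chain, or a hydroxyl group in place of the chain's amino group, also remains open.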